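The source may report more compounds than this note shows. Statements on the series, on what has been measured and on what is new or still open speak of the compounds shown alone.

Measured compounds and their values in a functional assay on CHO cells for agonist activity at Alpha-2C adrenergic receptor (Homo sapiens); on this read-out higher numbers stand for an effect only at larger amounts of compound and lower numbers for an effect already at smaller amounts:
- compound 1, `CC(Oc1ccccc1Br)C1=NCCN1`: compound 1 gives 10 nM
- compound 2, `C=C(C)c1ccccc1OC(C)C1=NCCN1`: compound 2 gives 115 nM
- compound 3, `C=COc1ccccc1OC(C)C1=NCCN1`: compound 3 gives 631 nM

Among these three, compound 1 has the lowest number in this assay, and both of its neighbours stand beyond the scatter: there is a 12-fold higher number from compound 1 to compound 2 (1.06 log units; beyond the scatter) and a 63-fold higher number from compound 1 to compound 3 (1.80 log units; beyond the scatter). The two replacements of bromo seen so far therefore both pushed the number up by a large amount, with the two non-bromo compounds differing from each other by a 5.5-fold higher number from compound 2 to compound 3 (0.74 log units; beyond the scatter).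

Compound 4, `CC(Oc1ccccc1S(C)(=O)=O)C1=NCCN1`, has not yet been measured in this assay. It differs from compound 1 in one place: methylsulfonyl in place of bromo on an aromatic carbon

The bearing steps are those from compound 1 to compound 2 and from compound 1 to compound 3, each a large rise on leaving bromo. Neither of them introduced methylsulfonyl, so the match is only by analogy, but both point in the same direction. A large rise in this assay is therefore expected from compound 1 to compound 4, namely a 50-fold higher number from compound 1 to compound 4 (1.70 log units; beyond the scatter). Compound 4 is estimated at 500 nM, with a range from 100 nM to 3000 nM.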

Compound 4, half-maximal effective concentration: 316 nM
Compound 4: the middle estimate sits 1.6-fold (0.20 log units) above what was measured; the measured number falls inside the stated range.
By their numbers in this assay, from the lowest: compound 1; then compound 2; then compounds 4 and 3 (each within the scatter of the next).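

In this assay, methylsulfonyl gives a third replacement of bromo on this aromatic carbon that raises the number by a large amount, with a 32-fold higher number from compound 1 to compound 4 (1.50 log units; beyond the scatter) on a change that brings in hydrogen-bond acceptors where bromo had none. The three replacements do not separate evenly, since a 2.0-fold lower number from compound 3 to compound 4 (0.30 log units; within the scatter) leaves methylsulfonyl and vinyloxy without a difference, while a 2.7-fold higher number from compound 2 to compound 4 (0.44 log units; beyond the scatter) puts methylsulfonyl modestly behind 1-methylethenyl. Nothing at hand explains why the number rises each time bromo leaves. Going by these compounds, whether chloro, methyl or trifluoromethyl on this carbon would stay close to compound 1 remains open. So does whether an amine or a carboxylic acid here would raise the number further, or whether any group at all would bring it lower than bromo does.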